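The source may report more compounds than this note shows. Statements on the series, on what has been measured and on what is new or still open speak of the compounds shown alone.

Measured so far in a physicochemical assay for lipophilicity, measured as octanol-water partition; a higher number here means a more lipophilic compound, a lower number a more polar compound:

Compound 1 `O=C(COc1cccc2ccccc12)N/N=C/c1cccc(O)c1`: 3.73
Compound 2 `COc1ccc(/C=N/NC(=O)COc2cccc3ccccc23)cc1OC`: 3.51

Compound 2 stands at 3.51, and compound 1, at 3.73, lies within the usual scatter of it, so these two numbers cannot be told apart. Compound 3 `COc1ccc(/C=N/NC(=O)COc2cccc3ccccc23)cc1` has not been measured yet. It differs from compound 2 in one place, where hydrogen takes the place of methoxy on an aromatic carbon (hydrogen in place of methoxy on an aromatic carbon). Among the compounds with values here, no measured pair here shows this kind of change, so the expectation rests only on the two values in hand, which sit close together. In this assay, the expected step of a number 0.09 log units higher from compound 2 to compound 3 (within the scatter) is a slight rise that stays within the scatter. For compound 3 the estimated value is 3.6, with an expected range from 3.25 to 3.95.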

Compound 3, partition coefficient: 3.77
The estimate for compound 3 lay 0.17 log units below the measured number, within the range that was stated.
By their numbers in this assay, from the lowest: compounds 2, 1 and 3 (each within the scatter of the next).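

In this assay, within the data shown here, the swap of methoxy for hydrogen, on an aromatic carbon ortho to a methoxy group, gives a number 0.26 log units higher from compound 2 to compound 3 (within the scatter) and so offers the first one-place comparison here, one that cannot separate the two groups at this position. Putting 4-methoxyphenyl in place of 3-hydroxyphenyl on the carbon with a double bond to nitrogen gives a number 0.04 log units higher from compound 1 to compound 3 (within the scatter) and likewise leaves the two compounds indistinguishable in this measurement. No measured evidence here bears on either step.

The compounds shown leave open whether an amine or a carboxylic acid on this aromatic carbon would give a step beyond the scatter. They also leave open whether a longer chain such as ethoxy or butoxy in place of methoxy would do so.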